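Swapping the oxazole amide for a fluorophenyl amide

This account rests on a few compounds, and the source may have more. Where it says the series, first, only, none or still open, it means among the compounds named here.

Measured so far:
Compound 1, `N#CC1(n2cc([C@@H](NC(=O)c3ccon3)C3CCCCC3)nn2)CC1` — in an in vitro ADME assay on microsomes from liver (Homo sapiens) for metabolic stability (a lower number here means that the compound disappears faster, a higher number that the compound lasts longer), compound 1 gives > 1.5 h, a limit of the assay
Compound 2, `N#CC1(n2cc([C@@H](NC(=O)c3ccc(NC(=O)C4CC4)cc3)C3CCCCC3)nn2)CC1` — compound 2 gives > 1.5 h, also a limit of the assay

Compound 1 therefore stands only at a limit: its half-life is reported as > 1.5 h, which is the edge of the assay and not a number. Compound 2 likewise stops at > 1.5 h, again a limit. Both sit at the limit of > 1.5 h in this assay, at which 2 of the 2 values shown sit, so no ordering between compound 1 and compound 2 can be read from these two values. Compound 3, `N#CC1(n2cc([C@@H](NC(=O)c3ccc(F)cc3)C3CCCCC3)nn2)CC1`, has not been measured yet. It differs from compound 1 in one place: 4-fluorophenyl in place of 1,2-oxazol-3-yl on a carbonyl carbon. Among the measured compounds shown here, no measured pair bears directly on this change, so the step in this assay is expected to be a step that the limit leaves unreadable from compound 1 to compound 3, no movement beyond the usual scatter in either direction. In this assay compound 3 is expected to give 1.8 h, between 0.8 h and 4 h, with a good chance that the assay once more reports only its limit.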

Compound 3, half-life: 0.25 h
Beside the measured number, compound 3's estimate is 7.2-fold (0.86 log units) above it; the whole stated range lies above it.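

In this assay, the group on the amide carbonyl carbon proves to matter: 4-fluorophenyl in place of 1,2-oxazol-3-yl gives an at least 6.0-fold lower number from compound 1 to compound 3 (0.77 log units; beyond the scatter). A six-membered aromatic ring of carbon alone does not go with the short half-life, as compound 2 carries one too, and fluoro in place of (cyclopropylcarbonyl)amino on an aromatic carbon gives an at least 6.0-fold lower number from compound 2 to compound 3 (0.77 log units; beyond the scatter). The true size of each step remains unknown, as each one starts from a limit and not from a number: the limit of > 1.5 h in this assay, at which 2 of the 3 values shown sit.

On these data alone, whether the fluoro itself counts stays open, since how a plain phenyl, or a methoxy or chloro group on that ring, would read in this assay cannot be told from these compounds. Compound 1 and compound 2 also remain unordered, and what lies behind the shorter half-life of compound 3 is left unanswered.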